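This account rests on a few compounds, and the source may have more. Where it says the series, first, only, none or still open, it means among the compounds named here.

Compound 1, whose structure is `CCN(C/C=C/C#CC(C)(C)C)Cc1cccc(OC[Si](C)(C)c2ccc(F)cc2)c1`, is the reference point here. In a functional assay on liver (Sus scrofa) for inhibition of squalene monooxygenase (Homo sapiens), using microsomes (on this read-out lower numbers stand for stronger inhibition and higher numbers for weaker inhibition), compound 1 gives 60 nM, the lowest number of the three measured, and its steps to both other compounds lie beyond the scatter, so it is the most potent of them. Compound 2, `CCN(C/C=C/C#CC(C)(C)C)Cc1cccc(OC[Si](C)(C)c2ccc(O)cc2)c1`, gives 8000 nM in this assay, and compound 3, `CCN(C/C=C/C#CC(C)(C)C)Cc1cccc(OC[Si](C)(C)c2ccc(C(=O)C(F)(F)F)cc2)c1`, gives 5000 nM. Both departures from compound 1 were costly: a 130-fold higher number from compound 1 to compound 2 (2.12 log units; beyond the scatter), and an 83-fold higher number from compound 1 to compound 3 (1.92 log units; beyond the scatter). Compounds 2 and 3 sit within the scatter of each other.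

The unmeasured compound 4 has the structure `CCN(C/C=C/C#CC(C)(C)C)Cc1cccc(OC[Si](C)(C)c2ccccc2-c2ccsc2)c1`. Its difference from compound 1 is 2-(thiophen-3-yl)phenyl in place of 4-fluorophenyl on a silicon. The two measured steps both show that altering the aromatic ring attached to the silicon can weaken inhibition sharply, and they bear on this change only loosely, since neither introduces a second aromatic ring or a thiophene. Among the measured compounds shown here, with no closer precedent, a moderate loss is the most reasonable expectation, with wide uncertainty. Compound 4 is therefore expected to give about 400 nM in this assay, within a range from 60 nM to 3000 nM, which corresponds to an estimated step of a 6.7-fold higher number from compound 1 to compound 4 (0.82 log units; beyond the scatter).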

Compound 4, half-maximal inhibitory concentration: 10000 nM
Compound 4: middle estimate off by 25-fold (1.40 log units), on the low side, outside the stated range (above it).
By their numbers in this assay, from the lowest: compound 1; then compounds 3, 2 and 4 (each within the scatter of the next).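

In this assay, among the compounds shown here, the earlier steps only swapped the fluoro for another group on the aromatic ring, whereas here the whole 4-fluorophenyl on the silicon gives way to 2-(thiophen-3-yl)phenyl, and inhibition again falls sharply (a 170-fold higher number from compound 1 to compound 4 (2.22 log units; beyond the scatter)). This larger group, which brings a second aromatic ring, a thiophene, cannot be told apart from the two earlier replacements, since both remaining steps lie within the scatter (a 1.3-fold higher number from compound 2 to compound 4 (0.10 log units; within the scatter); a 2.0-fold higher number from compound 3 to compound 4 (0.30 log units; within the scatter)). Three quite different changes to the group on the silicon therefore end up at the same weak level, and among these four compounds only the 4-fluorophenyl group gives strong inhibition.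

Nothing measured here explains why each of these changes costs so much. The compounds shown leave open which part of the new group accounts for the loss, and a plain phenyl, a 4-chlorophenyl or a thiophen-3-yl alone on the silicon would help separate the effect of the second ring from that of the thiophene itself.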